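A few compounds are considered here, and "the series" means these few. Any claim that something is new, unique, unknown or untested is made for them only; others in the source may bear on it.

Compound 1 `O=C(/C=C/c1cccc(O)c1)CC(=O)/C=C/c1cccc(O)c1O`: 38000 nM
Compound 2 `O=C(/C=C/c1ccc(O)c(O)c1)CC(=O)/C=C/c1cc(O)ccc1O`: 51000 nM
Compound 3 `O=C(/C=C/c1ccc(O)c(O)c1)/C=C/c1ccccc1O`: 34000 nM

All three values come from an ADME assay on PC-12 cells (Rattus norvegicus) for cytotoxicity, read by WST assay, with a stated time of 24 h; on this read-out higher numbers stand for lower toxicity in this test and lower numbers for higher toxicity in this test. In this assay compound 3 gives 34000 nM, which lies within the scatter of the values for compound 1 and compound 2. The three measured compounds therefore cannot be ranked on these numbers, and compound 3 stands level with the other two.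

The next compound to be measured is compound 4 `O=C(/C=C/c1ccc(O)cc1)/C=C/c1ccc(O)c(O)c1`. It has the same atoms as compound 3, joined differently: 4-hydroxyphenyl in place of 2-hydroxyphenyl on a double-bonded chain carbon bound to a double-bonded chain carbon. In words, 4-hydroxyphenyl stands in place of 2-hydroxyphenyl on a double-bonded chain carbon bound to a double-bonded chain carbon.

Going by the values given here, no pair of measured compounds differs in one place only, so the series offers no direct step to read this change against. Among the compounds with values here, the only guide is the narrow spread of the values, with compound 3 as the anchor at 34000 nM. No step beyond the scatter is expected in this assay, in either direction. The estimated shift, a 1.1-fold higher number from compound 3 to compound 4 (0.02 log units; within the scatter), is expected to stay within the scatter. For compound 4 the expected value is 36000 nM, with an estimated range of 16000 nM to 80000 nM.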

Compound 4, half-maximal cytotoxic concentration in the PC-12 assay: 12000 nM
Beside the measured number, compound 4's estimate is 3.0-fold (0.48 log units) above it; the measured number lies below the stated range.
By their numbers in the PC-12 assay, from the lowest: compound 4; then compounds 3, 1 and 2 (each within the scatter of the next).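

In the PC-12 assay, 4-hydroxyphenyl in place of 2-hydroxyphenyl on a double-bonded chain carbon bound to a double-bonded chain carbon gives a 2.8-fold lower number from compound 3 to compound 4 (0.45 log units; beyond the scatter). Going by these compounds alone, this is the first step beyond the scatter, and it shows that the read-out at this position responds to a change that only rejoins the same atoms, which the earlier compounds, all within the scatter of one another, could not show. In a physicochemical assay for solubility, using the shake flask method, with a stated time of 12 h (on this read-out higher numbers stand for higher solubility and lower numbers for lower solubility), compound 3 gives 111000 nM and compound 4 gives 19000 nM. The same change also lowers the number in the physicochemical assay, so lower solubility and the lower cytotoxicity number go together in this pair, though a single pair cannot show that one drives the other: the measured solubility of compound 3, 111000 nM, and of compound 4, 19000 nM, a 5.8-fold lower number (0.77 log units; beyond the scatter).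

Within the data shown here, it remains open whether the change gives a step of similar size on the longer chain shared by compound 1 and compound 2, where no matched pair is available. Also open, going by these compounds, is how an amine or a carboxylic acid in place of the hydroxyl of 4-hydroxyphenyl would read in the PC-12 assay and in the physicochemical assay, and whether the two read-outs would still move together.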